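A few compounds are considered here, and "the series" means these few. Any claim that something is new, unique, unknown or untested is made for them only; others in the source may bear on it.

Working notes on a series of four compounds built on one shared core. Compound 1 `O=C1O[C@H]([C@@H](O)Cn2cc(-c3cc(C(F)(F)F)cc(C(F)(F)F)c3)nn2)C(OCc2ccccc2)=C1OCc1ccccc1` and compound 3 `O=C1O[C@H]([C@@H](O)Cn2cc(-c3cccc(O)c3)nn2)C(OCc2ccccc2)=C1OCc1ccccc1` carry the saturated, hydroxy-bearing side chain; in a functional assay on CFPAC-1 cells (Homo sapiens) for antiproliferative activity, read by MTT assay, with a stated time of 72 h (a lower number here means a stronger inhibitor, a higher number a weaker inhibitor), compound 1 gives 66500 nM and compound 3 gives 54100 nM. These two numbers lie within the usual scatter of each other, so no order between them is read. Among the measured compounds shown here, compound 2 `O=C1O/C(=C\Cn2cc(-c3cc(F)cc(F)c3)nn2)C(OCc2ccccc2)=C1OCc1ccccc1` carries the alkene side chain with the 3,5-difluorophenyl group; in this assay compound 2 gives "not active" (no number reported), with no number, so no single value places it on the scale, and no step between measured compounds exists for the change now considered. Compound 4 `O=C1O/C(=C\Cn2cc(-c3cccc(O)c3)nn2)C(OCc2ccccc2)=C1OCc1ccccc1` is the next compound: 3-hydroxyphenyl in place of 3,5-difluorophenyl on an aromatic carbon. For the measured compounds named here, with compound 2 inactive and no measured step for this exchange, neither the direction nor the size of the step from compound 2 to compound 4 can be stated with confidence; the hydroxyphenyl analogue on the alkene chain is expected to remain weak, since compound 3 with the same aryl group gives only 54100 nM. Compound 4 is therefore expected to give 90000 nM in this assay, with a range from 40000 nM to 200000 nM, and a real chance that only inactivity is reported.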

Compound 4, half-maximal inhibitory concentration: 33700 nM
Compound 4: middle estimate off by 2.7-fold (0.43 log units), on the high side, and the stated range ends above it.
By their numbers in this assay, from the lowest: compounds 4, 3 and 1 (each within the scatter of the next).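

Among the compounds shown here, compound 2 has no number in this assay, so no step to compound 4 can be read from this result. The compounds shown leave open how 3-hydroxyphenyl and 3,5-difluorophenyl compare on the same side chain in this assay. No supporting evidence is available that bears on the result for compound 4.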